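One Flipped Stereocentre, Lipophilicity Expected Unchanged

The source may report more compounds than this note shows. Statements on the series, on what has been measured and on what is new or still open speak of the compounds shown alone.

Compound 1, `CC(=O)OC[C@H]1O[C@@H](S[C@H]2CC(=O)[C@@H]3OC[C@H]2O3)[C@H](OC(C)=O)[C@@H](OC(C)=O)[C@@H]1OC(C)=O`: -1.13
Compound 2, `O=C1C[C@H](S[C@@H]2O[C@H](CO)[C@@H](O)[C@H](O)[C@H]2O)[C@H]2CO[C@@H]1O2`: -2.05
Compound 3, `O=C(O)c1ccccc1S[C@H]1CC(=O)[C@@H]2OC[C@H]1O2`: 1.28

Of the compounds shown here, three have been measured in a physicochemical assay for lipophilicity; on this read-out higher numbers stand for higher lipophilicity and lower numbers for lower lipophilicity. Compound 1 holds the second highest of the three numbers: compound 2 lies lower and compound 3 lies higher, both by more than the usual scatter. Compound 4, `CC(=O)OC[C@H]1O[C@@H](S[C@H]2CC(=O)[C@@H]3OC[C@H]2O3)[C@H](OC(C)=O)[C@@H](OC(C)=O)[C@H]1OC(C)=O`, is not yet measured. It differs from compound 1 in this way: the two compounds have the same atoms and bonds and differ only in configuration as drawn: 1 of 8 stereo elements differ; a stereocentre at a saturated ring carbon is drawn R in compound 1 and S in compound 4. Going by the values given here, no pair of measured compounds differs in a single place, so no measured step shows what such a flip does here. With nothing leaving and nothing entering, the expectation for compound 4 is a number close to that of compound 1 at -1.13. Compound 4 is expected to give -1.13, between -1.55 and -0.7. The expected step of no change at the digits printed from compound 1 to compound 4 (within the scatter) is none beyond the scatter.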

Compound 4, partition coefficient: -1.13
Beside the measured number, compound 4's estimate shows no gap at the digits printed; the range from low to high includes it.
By their numbers in this assay, from the lowest: compound 2; then compounds 1 and 4 (each within the scatter of the next); then compound 3.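

In this assay, going by these compounds alone, flipping the stereocentre at a saturated ring carbon gives no change at the digits printed from compound 1 to compound 4 (within the scatter), the first step here that changes a single place. This step can be read as the effect of the flip alone, because nothing else separates the two structures: the fact that compounds 1 and 4 differ only in the configuration as drawn. At this ring carbon, the configuration as drawn makes no difference to the read-out for this pair.

From the compounds shown here alone, whether the same flip would leave the number unchanged in compound 2 remains open. So does what an amine at this ring carbon would do.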